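A few compounds are considered here, and "the series" means these few. Any claim that something is new, unique, unknown or untested is made for them only; others in the source may bear on it.

Measured in a functional assay on HeLa cells (Homo sapiens) for cytotoxicity, read by sulforhodamine B assay, with a stated time of 48 h; on this read-out higher numbers stand for weaker inhibition and lower numbers for stronger inhibition:

compound 1, `CCCC[C@@H](/C=C\[C@@H]1OC(=O)C=C[C@@H]1OC(C)=O)OC(C)=O`, gives 3200 nM
compound 2, `CCCC[C@H](/C=C\[C@@H]1OC(=O)C=C[C@@H]1O)OC(C)=O`, gives 1400 nM

Compound 2 holds the lowest of the two numbers; its nearest neighbour is compound 1, whose number is higher by a margin that lies beyond the scatter. Among the compounds with values here, no step between the two measured compounds is drawn, as they differ in more than one place, so only the two values themselves can be compared.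

Compound 3, `CCCC[C@H](/C=C\[C@@H]1OC(=O)C=C[C@@H]1OC(C)=O)OC(C)=O`, is not yet measured. It differs from compound 2 by acetyl in place of hydrogen on an oxygen on a saturated carbon. Within the data shown here, no measured pair shows this change on its own. The expectation is a small step from compound 2, toward a higher number, of about a 1.8-fold higher number from compound 2 to compound 3 (0.25 log units; within the scatter), close to the edge of the scatter. On that basis compound 3 is estimated at 2500 nM in this assay, with a range from 1000 nM to 6000 nM.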

Compound 3, half-maximal inhibitory concentration: 700 nM
Compound 3: the middle estimate sits 3.6-fold (0.55 log units) above what was measured; the whole stated range lies above it.
By their numbers in this assay, from the lowest: compounds 3 and 2 (each within the scatter of the next); then compound 1.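

In this assay, acetyl in place of hydrogen on an oxygen on a saturated carbon gives a 2.0-fold lower number from compound 2 to compound 3 (0.30 log units; within the scatter), so hydroxy and acetoxy at this position are not separated by this pair. The configuration at the saturated chain carbon, which the earlier pair could not isolate, does register: a 4.6-fold lower number from compound 1 to compound 3 (0.66 log units; beyond the scatter). That gap can be assigned to the single stereocentre drawn S in compound 1 and R in compound 3, with no group changing: the fact that compounds 1 and 3 differ only in the configuration as drawn.

Still open, as far as these compounds go, is whether the configuration at the chain carbon counts the same way when hydroxy replaces acetoxy at the position that separates compound 2 from compound 3. Also open, from the compounds shown here alone, is how an amine or a longer acyl chain on that oxygen would read in this assay.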